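A ring methyl gives way to hydrogen

The compounds below may be only part of what the source reports. "The series", "measured", "known", "first", "only" and "open" are said of these compounds alone.

In an ADME assay on Caco-2 cells (Homo sapiens) for permeability, read by LC-MS, with a stated time of 2 h, at pH 7.4, tested at 10 uM (a higher number here means that the compound crosses the layer faster, a lower number that the compound crosses the layer more slowly), compound 3 (`C[C@@H]1Cn2c(nnc2C(F)(F)F)CN1C(=O)c1cccc(Cc2n[nH]c(=O)c3c2CCCC3)c1`) gives 0.3 10^-6 cm/s, the lowest of the three numbers available. Compound 1 (`C[C@H]1Cn2c(nnc2C(F)(F)F)CN1C(=O)c1cccc(Cc2n[nH]c(=O)c3c2CCCC3)c1`) gives 0.9 10^-6 cm/s, and compound 2 (`O=C(c1cccc(Cc2n[nH]c(=O)c3ccccc23)c1)N1CCn2c(nnc2C(F)(F)F)C1`) gives 1.3 10^-6 cm/s. Compound 4 (`O=C(c1cccc(Cc2n[nH]c(=O)c3c2CCCC3)c1)N1CCn2c(nnc2C(F)(F)F)C1`) has not yet been measured. It differs from compound 3 by hydrogen in place of methyl on a saturated ring carbon. Among the compounds with values here, only one measured step touches this carbon, a 3.0-fold lower number from compound 1 to compound 3 (0.48 log units; beyond the scatter), and it goes with the fact that compounds 1 and 3 differ only in the configuration as drawn. Within the data shown here, that step shows that this carbon matters in this assay, but no measured pair shows the methyl actually removed, so the size of the new step remains uncertain. Among the measured compounds shown here, compound 3 lies at the low end of the step from compound 1 at 0.9 10^-6 cm/s, so a rise of modest size, no larger than that step, is expected. The expected change is a 2.3-fold higher number from compound 3 to compound 4 (0.37 log units; beyond the scatter). For compound 4 the estimate is 0.7 10^-6 cm/s, with an expected range from 0.3 10^-6 cm/s to 1.6 10^-6 cm/s.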

Compound 4, apparent permeability: 0.4 10^-6 cm/s
For compound 4 the middle estimate is 1.8-fold (0.24 log units) above the measured one, and the stated range covers the measured number.
By their numbers in this assay, from the lowest: compounds 3 and 4 (each within the scatter of the next); then compounds 1 and 2 (each within the scatter of the next).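

In this assay, hydrogen in place of methyl on this saturated ring carbon gives a 1.3-fold higher number from compound 3 to compound 4 (0.12 log units; within the scatter), so removing the methyl drawn R leaves the number within the scatter. The same replacement gives a 2.3-fold lower number from compound 1 to compound 4 (0.35 log units; beyond the scatter) when the methyl is drawn S, so the outcome of removing the methyl depends on its configuration, and the pair that first pointed to this carbon is the one where: the fact that compounds 1 and 3 differ only in the configuration as drawn. A second place also matters, as the group on the saturated chain carbon bound to an aromatic carbon gives a 3.3-fold lower number from compound 2 to compound 4 (0.51 log units; beyond the scatter).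

The compounds shown leave open how an ethyl or a hydroxymethyl group on this carbon would compare with methyl and hydrogen. They also leave open whether either methyl configuration would give the same steps on the core of compound 2.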